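Side chain on the nitrogen: compound 3 to compound 4

The source may report more compounds than this note shows. Statements on the series, on what has been measured and on what is new or still open speak of the compounds shown alone.

In a functional assay on K562 cells (Homo sapiens) for cytotoxicity, read by trypan blue exclusion, with a stated time of 96 h (on this read-out lower numbers stand for stronger inhibition and higher numbers for weaker inhibition), compound 3 `COC(=O)C(Nc1cc(CS(=O)(=O)/C=C/c2c(OC)cc(OC)cc2OC)ccc1OC)c1ccc(Br)cc1` gives 200 nM, the lowest of three numbers, against compound 2 `COC(=O)C(C)(C)Nc1cc(CS(=O)(=O)/C=C/c2c(OC)cc(OC)cc2OC)ccc1OC` at 800 nM and compound 1 `COC(=O)CCNc1cc(CS(=O)(=O)/C=C/c2c(OC)cc(OC)cc2OC)ccc1OC` at 1000 nM. Next is compound 4 `COc1cc(OC)c(/C=C/S(=O)(=O)Cc2ccc(OC)c(NC(C(=O)O)c3ccccc3)c2)c(OC)c1`: carboxy(phenyl)methyl in place of (4-bromophenyl)(methoxycarbonyl)methyl on a nitrogen on an aromatic ring. For the measured compounds named here, two measured steps bear on it, a 5.0-fold lower number from compound 1 to compound 3 (0.70 log units; beyond the scatter) and a 4.0-fold lower number from compound 2 to compound 3 (0.60 log units; beyond the scatter), both modest and both ending at the (4-bromophenyl)(methoxycarbonyl)methyl group, while a 1.3-fold lower number from compound 1 to compound 2 (0.10 log units; within the scatter) stays within the scatter. Going by the values given here, no measured step removes the bromine alone or replaces the ester with a carboxy group. Taking compound 3 at 200 nM as the base, a modest move to a higher number is expected in this assay, with wide uncertainty. The estimated step is a 2.5-fold higher number from compound 3 to compound 4 (0.40 log units; beyond the scatter). Compound 4 is estimated at 500 nM, with an expected range of 100 nM to 2000 nM.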

Compound 4, half-maximal inhibitory concentration: 15 nM
For compound 4 the middle estimate is 33-fold (1.52 log units) above the measured one; the whole stated range lies above it.
By their numbers in this assay, from the lowest: compound 4; then compound 3; then compounds 2 and 1 (each within the scatter of the next).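

Side chain on the nitrogen: what compound 4 adds

In this assay, the side chain on the nitrogen spans a much wider range than the first three compounds showed, with carboxy(phenyl)methyl giving a 13-fold lower number from compound 3 to compound 4 (1.12 log units; beyond the scatter) and a 53-fold lower number from compound 2 to compound 4 (1.73 log units; beyond the scatter) and a 67-fold lower number from compound 1 to compound 4 (1.82 log units; beyond the scatter) as large steps. Compound 4 is the only carboxylic acid among the compounds shown, and it has the lowest number of the four without any bromine. Nothing available here explains this gain.

On these data alone, the step to compound 4 exchanges the methyl ester for the carboxy group and removes the bromine together, so the share of each remains open. Also open, as far as these compounds go, is how the 4-bromophenyl acid, the phenyl methyl ester, or a primary amide in place of the carboxy group would read.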